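This account rests on a few compounds, and the source may have more. Where it says the series, first, only, none or still open, it means among the compounds named here.

Measured so far:
compound 1, `COc1ccc(N2C(=O)CSC2c2sc(-c3ccccc3)nc2C)cc1` — 67.1%
compound 2, `Cc1nc(-c2ccccc2)sc1C1SCC(=O)N1c1ccc(F)c(Cl)c1` — 28.6%
compound 3, `COc1ccc(N2C(=O)CSC2c2sc(Cc3ccc(Cl)cc3)nc2C)cc1` — 55.9%

In a functional assay on the whole organism (strain Wistar albino) for inhibition, with Rattus norvegicus as the target, read by paw edema, with stated times of 1 h and 4 h, at a dose of 40 mg/kg by the oral route (on this read-out lower numbers stand for less inhibition and higher numbers for more inhibition at the one dose given (going by the name of the read-out)), compound 3 stands second highest of the three numbers: compound 1 lies above it by a number 11.2 percentage points lower from compound 1 to compound 3 (beyond the scatter), and compound 2 lies well below it, the gap between these two values being beyond the scatter.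

Compound 4, `Cc1nc(Cc2ccc(Cl)cc2)sc1C1SCC(=O)N1c1ccc(Cl)cc1`, has not been measured. It differs from compound 3 in one place: chloro in place of methoxy on an aromatic carbon

Among the compounds with values here, the one measured step that bears on this change is the replacement on the same nitrogen-bound ring, where 3-chloro-4-fluorophenyl in place of 4-methoxyphenyl gave a number 38.5 percentage points lower from compound 1 to compound 2 (beyond the scatter). That change is not the same as chloro in place of methoxy, since it brings two halogens rather than one, but it is the only indication available, and it points downward. The step from compound 1 to compound 3 concerns a different position and does not bear on it.

A decrease beyond the scatter is therefore expected, though smaller than the step from compound 1 to compound 2, since only one halogen enters: compound 4 is estimated at 38% (range 22% to 55%), which would mean an expected step of a number 17.9 percentage points lower from compound 3 to compound 4 (beyond the scatter).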

Compound 4, a percentage reported as inhibition, in the whole organism at one dose (the size of the read-out at that dose, not a potency): 53.9%
Estimate against measurement, compound 4: 15.9 percentage points below; the range from low to high includes it.
By their numbers in this assay, from the lowest: compound 2; then compounds 4 and 3 (each within the scatter of the next); then compound 1.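

In this assay, with 4-chlorobenzyl held on the shared core, the change from 4-methoxyphenyl to 4-chlorophenyl gives a number 2 percentage points lower from compound 3 to compound 4 (within the scatter), so at this place a single chloro can stand for the methoxy without a step beyond the scatter. The earlier change on this ring, which gave a number 38.5 percentage points lower from compound 1 to compound 2 (beyond the scatter), brought in 3-chloro-4-fluorophenyl on a core carrying phenyl instead of 4-chlorobenzyl, so a halogen on this ring does not by itself go with a large step. No measurement at hand accounts for the difference between these two steps.

From the compounds shown here alone, whether the large step belongs to the added 3-chloro substituent, the 4-fluoro group or the phenyl-bearing core stays open. Also open, going by these compounds, is how a dimethylamino group or a carboxylic acid would read at this place on the ring.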